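This account rests on a few compounds, and the source may have more. Where it says the series, first, only, none or still open, it means among the compounds named here.

Working notes on the series. Compound 1 `O=C1O[C@H]([C@@H](O)Cn2cc(-c3cccc(O)c3)nn2)C(OCc2ccccc2)=C1OCc1ccccc1` gives in a functional assay on A549 cells (Homo sapiens) for antiproliferative activity, read by MTT assay, with a stated time of 72 h (on this read-out higher numbers stand for weaker inhibition and lower numbers for stronger inhibition), a value of 59900 nM. Compound 2 `COc1ccccc1-c1cn(C[C@H](O)[C@H]2OC(=O)C(OCc3ccccc3)=C2OCc2ccccc2)nn1` reaches in this assay only a limit, > 100000 nM, not a number. Compound 3 `COc1ccccc1-c1cn(C/C=C2\OC(=O)C(OCc3ccccc3)=C2OCc2ccccc2)nn1` likewise reaches in this assay only a limit, > 100000 nM. The change 3-hydroxyphenyl in place of 2-methoxyphenyl on an aromatic carbon produced an at least 1.6-fold lower number from compound 2 to compound 1 (0.22 log units; that floor lies within the scatter). The difference between the cores of compound 2 and compound 3 is not broken down here. Compound 4 `O=C1O/C(=C\Cn2cc(-c3cccc(O)c3)nn2)C(OCc2ccccc2)=C1OCc1ccccc1` carries the same change on the core of compound 3: 3-hydroxyphenyl in place of 2-methoxyphenyl on an aromatic carbon. Going by the values given here, of the values so far, note (the limit of > 100000 nM in this assay, at which 2 of the 3 values shown sit). For compound 4 the step is expected to be a number no higher from compound 3 to compound 4 (the limit leaves the size open), resting on an at least 1.6-fold lower number from compound 2 to compound 1 (0.22 log units; that floor lies within the scatter), which stayed within scatter. Compound 4 is therefore estimated at 100000 nM in this assay, with the likely range running from 40000 nM to 250000 nM.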

Compound 4, half-maximal inhibitory concentration: 23300 nM
Compound 4: the middle estimate sits 4.3-fold (0.63 log units) above what was measured; the whole stated range lies above it.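

In this assay, 3-hydroxyphenyl in place of 2-methoxyphenyl gives an at least 4.2-fold lower number from compound 3 to compound 4 (0.63 log units; beyond the scatter), a step beyond the scatter on the core of compound 3. This does not establish that the change has a larger effect on that core than on the core of compound 1, and the two steps cannot be ranked by size: the same change on two cores in this assay, an at least 1.6-fold lower number (0.22 log units; that floor lies within the scatter) from compound 2 to compound 1 and an at least 4.2-fold lower number (0.63 log units; beyond the scatter) from compound 3 to compound 4; the limit leaves it open whether they differ Both steps start from a limit and not from a number, which leaves their true sizes unknown: the limit of > 100000 nM in this assay, at which 2 of the 4 values shown sit.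

The oxygen substituent and its place on the phenyl ring change together in this step, and the compounds shown do not separate the two. Going by these compounds, how an aminophenyl or a carboxyphenyl group on the same aromatic carbon would read on either core also remains open.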